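The source may report more compounds than this note shows. Statements on the series, on what has been measured and on what is new or still open speak of the compounds shown alone.

Two hydroxamic acids carrying the same core have been measured in a functional assay on NCI-H23 cells (Homo sapiens) for inhibition, read by sulforhodamine B assay; a lower number here means a stronger inhibitor of growth, a higher number a weaker inhibitor of growth. Compound 1, `O=C(CCC1=CCN(CCCc2ccc(Br)cc2)C1=O)NO`, gives 2520 nM in this assay. Compound 2, `Cc1ccc(CN2CC=C(CCC(=O)NO)C2=O)cc1`, gives 2500 nM in this assay, and this number stands so close to that of compound 1 that the two cannot be told apart within the scatter of the measurement. Within the data shown here, no step between these two compounds can be drawn, because they differ in more than one place. Compound 3, `N#Cc1ccc(CN2CC=C(CCC(=O)NO)C2=O)cc1`, has not yet been measured in this assay. It differs from compound 2 in one place: cyano in place of methyl on an aromatic carbon. Among the measured compounds shown here, with no comparable step among the measured compounds, the expectation rests on the closeness of compound 1 and compound 2 alone, and compound 3 is expected to fall near compound 2, with a step from compound 2 to compound 3 of no change at the digits printed from compound 2 to compound 3 (within the scatter), not beyond the scatter in either direction. Compound 3 is therefore estimated at 2500 nM in this assay, within a range from 1000 nM to 6300 nM.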

Compound 3, concentration for 50% growth inhibition: 2320 nM
Compound 3: middle estimate off by 1.1-fold (0.03 log units), on the high side, within the range that was stated.
By their numbers in this assay, from the lowest: compounds 3, 2 and 1 (each within the scatter of the next).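

Compound 3 gives the series its first step that changes a single place: in this assay cyano in place of methyl on an aromatic carbon, para to a large group, gives a 1.1-fold lower number from compound 2 to compound 3 (0.03 log units; within the scatter) and so leaves the reading unchanged within the scatter. The earlier pair could not show this, since compound 1 and compound 2 differ in more than one place and their closeness could not be tied to any one group. At this position, then, a nitrile with one more heavy atom and one hydrogen-bond acceptor reads the same as methyl, and no measurement at hand bears on why that is so.

Going by these compounds, whether an amine or a carboxylic acid on this same aromatic carbon would also read alike remains open. So does the outcome of moving the cyano to another carbon of the ring, or of replacing the hydroxamic acid with a carboxylic acid.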